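Fluoro for Trifluoromethyl: Estimating Compound 4

This account rests on a few compounds, and the source may have more. Where it says the series, first, only, none or still open, it means among the compounds named here.

Three compounds built on related cores were tested in a functional assay on HepG2 cells (Homo sapiens) for cytotoxicity, read by MTT assay, with a stated time of 24 h; on this read-out higher numbers stand for weaker inhibition and lower numbers for stronger inhibition. Compound 1 `O=C1/C(=C/c2cccnc2)CNC/C1=C\c1ccccc1F` gives 21000 nM, and compound 2 `O=C1/C(=C/c2cccnc2)CNC/C1=C\c1ccccc1C(F)(F)F` gives 5020 nM. They differ by a single change, (fluoro in place of trifluoromethyl on an aromatic carbon), which produced a 4.2-fold higher number from compound 2 to compound 1 (0.62 log units; beyond the scatter). Compound 3 `O=C1/C(=C/c2ccncc2)CN(S(=O)(=O)c2ccc(C(F)(F)F)cc2)C/C1=C\c1ccccc1C(F)(F)F` gives 3240 nM; its core differs from that of compound 2 in more than one place, and that difference is not broken down here. Compound 3 and compound 2 lie within the usual scatter of each other, while compound 1 sits beyond that scatter from both.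

Compound 4 `O=C1/C(=C/c2ccncc2)CN(S(=O)(=O)c2ccc(F)cc2)C/C1=C\c1ccccc1C(F)(F)F` has not yet been measured. It differs from compound 3 by fluoro in place of trifluoromethyl on an aromatic carbon. For the measured compounds named here, this is the same kind of change as the one from compound 2 to compound 1, but not the same: there the group sat ortho to a large group, here it sits para to a large group. For compound 4 the expected step is a 3.1-fold higher number from compound 3 to compound 4 (0.49 log units; beyond the scatter), resting on the measured 4.2-fold higher number from compound 2 to compound 1 (0.62 log units; beyond the scatter) while allowing for the different surroundings. Compound 4 is therefore estimated at 10000 nM, most likely between 4000 nM and 30000 nM.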

Compound 4, half-maximal inhibitory concentration: 4010 nM
Estimate against measurement, compound 4: 2.5-fold (0.40 log units) above; the measured number falls inside the stated range.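

In this assay, the swap of trifluoromethyl for fluoro gives a 1.2-fold higher number from compound 3 to compound 4 (0.09 log units; within the scatter), so the two compounds cannot be told apart on this read-out. For the compounds shown here, the same kind of swap therefore does not carry over at the same size from one core to the other: the same change on two cores in this assay, a 4.2-fold higher number (0.62 log units; beyond the scatter) from compound 2 to compound 1 and a 1.2-fold higher number (0.09 log units; within the scatter) from compound 3 to compound 4, 3.4-fold (0.53 log units) apart, beyond the scatter of two such steps With only one pair on each core, this shows that the size of the step depends on its surroundings, but not which difference between the two pairs matters, whether where the swap sits on its ring or some other part of the core.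

From the compounds shown here alone, it remains open how a chloro, a methoxy or an amine would read in this assay if it took the place of the fluoro in the 4-fluorophenyl group of compound 4. A third core carrying the same swap would also be needed to tell which of the two step sizes is more typical of this series.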